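Swapping cyclohexyl for chloro on an acylguanidine benzamide

A few compounds are considered here, and "the series" means these few. Any claim that something is new, unique, unknown or untested is made for them only; others in the source may bear on it.

Measured compounds:
- compound 1 `Cc1c(C(=O)N=C(N)N)ccc(Cl)c1S(C)(=O)=O`: 1300 nM
- compound 2 `CS(=O)(=O)c1cc(C(=O)N=C(N)N)ccc1C1CCCCC1`: 340 nM

Both compounds were tested in a functional assay for inhibition of sodium/hydrogen exchanger (Oryctolagus cuniculus); on this read-out higher numbers stand for weaker inhibition and lower numbers for stronger inhibition. Compound 2 shows the lower of the two numbers; compound 1 stands a clear distance above it, and that gap is beyond the usual scatter of this assay. Only these two values are known, and they differ in more than one place, so no single change can be tied to the gap.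

Compound 3 `CS(=O)(=O)c1cc(C(=O)N=C(N)N)ccc1Cl` has not been measured yet. It differs from compound 2 in one place: chloro in place of cyclohexyl on an aromatic carbon. A much larger group is replaced by a much smaller one, so some loss of inhibition is expected. The step from compound 2 to compound 3 in this assay is estimated at a 2.4-fold higher number from compound 2 to compound 3 (0.37 log units; beyond the scatter), toward weaker inhibition. Compound 3 is expected to give about 800 nM, with a range from 250 nM to 2500 nM.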

Compound 3, half-maximal inhibitory concentration: 380 nM
Compound 3: the middle estimate sits 2.1-fold (0.32 log units) above what was measured; measured number inside the range.
By their numbers in this assay, from the lowest: compounds 2 and 3 (each within the scatter of the next); then compound 1.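

At this position, on an aromatic carbon ortho to a methylsulfonyl group, cyclohexyl and chloro cannot be told apart in this assay, with a 1.1-fold higher number from compound 2 to compound 3 (0.05 log units; within the scatter), so the ring of six carbons and the single chlorine sit within the scatter of each other. Going by these compounds alone, compound 3 also provides the first comparison that changes only one place, hydrogen in place of methyl on an aromatic carbon, and this gives a 3.4-fold lower number from compound 1 to compound 3 (0.53 log units; beyond the scatter), so the loss of that methyl goes with stronger inhibition here. Within the data shown here, nothing measured so far explains either step.

The compounds shown leave open how an amine, a carboxylic acid or a cyclopropyl group would read at the place held by chloro and cyclohexyl. They also leave open whether the methyl step would look the same with cyclohexyl in place of chloro.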